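Adding a phenyl group to compound 1

The source may hold more compounds than are shown below. What is called first, only, known or untested is meant among the compounds shown, and "the series" means these compounds.

Compound 1 `CC(C)c1ccc(OC(C)(Cc2ccccc2)C(=O)O)cc1`: > 10 mg/kg (a limit)
Compound 2 `CC(C)c1ccc(OC(C)(Cc2ccc(Cl)cc2)C(=O)O)cc1`: 1 mg/kg; 1 mg/kg; 1 mg/kg (3 entries)
Compound 3 `CCCc1ccc(CC(C)(Oc2ccc(C(C)C)cc2)C(=O)O)cc1`: 0.5 mg/kg

In a functional assay on the whole organism for inhibition, with Rattus norvegicus as the target (a lower number here means that less compound is needed, a higher number that more compound is needed for the effect), compound 1 reads > 10 mg/kg, which is a limit and not a number. Compound 4 `CC(C)c1ccc(OC(C)(Cc2ccccc2-c2ccccc2)C(=O)O)cc1` keeps the core of compound 1 with one change: phenyl in place of hydrogen on an aromatic carbon. The closest measured change, propyl in place of hydrogen on an aromatic carbon, gave an at least 20-fold lower number from compound 1 to compound 3 (1.30 log units; beyond the scatter). That large step points towards a lower number in this assay. Going by the values given here, no measured step, however, covers a group placed ortho to a large group, so the expected gain is smaller and less certain. The expected step is an at least 3.3-fold lower number from compound 1 to compound 4 (0.52 log units; beyond the scatter). The estimate for compound 4 is 3 mg/kg, with an expected range of 0.5 mg/kg to 15 mg/kg.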

Compound 4, dose for half-maximal effect: 10 mg/kg
Beside the measured number, compound 4's estimate is 3.3-fold (0.52 log units) below it; the range from low to high includes it.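

Phenyl placed ortho to a large group gives compound 4 a real number, 10 mg/kg, in this assay. The propyl change gave an at least 20-fold lower number from compound 1 to compound 3 (1.30 log units; beyond the scatter), a clear drop that this phenyl cannot be shown to match. The phenyl change gave a number no higher from compound 1 to compound 4 (the limit leaves the size open). The size of the step from compound 1 cannot be read, because its value is only a limit: the limit of > 10 mg/kg in this assay, at which 1 of the 4 values shown sits.

Open, from the compounds shown here alone, is whether a smaller group at this same place, such as methyl or methoxy, would give a lower number than phenyl. Also open, going by these compounds, is how phenyl would read on a different carbon of this ring.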